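Fluoro added on the anilino ring of an acrylamide

The source may hold more compounds than are shown below. What is called first, only, known or untested is meant among the compounds shown, and "the series" means these compounds.

Of the compounds shown here, three share a core and have been tested in a functional assay on MDA-MB-231 cells (Homo sapiens) for inhibition, read by MTT assay, with a stated time of 72 h; a lower number here means a stronger inhibitor, a higher number a weaker inhibitor. Compound 1 `O=C(CSc1nc(Nc2ccccc2)c2ccccc2n1)Nc1cccc(Cl)c1` gives 16500 nM in this assay. Compound 2 `C=CC(=O)Nc1cccc(NC(=O)CSc2nc(Nc3ccccc3)c3ccccc3n2)c1` differs from compound 1 by (vinylcarbonyl)amino in place of chloro on an aromatic carbon, and in this assay compound 2 gives 10200 nM; the step of a 1.6-fold lower number from compound 1 to compound 2 (0.21 log units; within the scatter) stays within the scatter. Compound 3 `O=C(CSc1nc(Nc2ccccc2)c2ccccc2n1)Nc1ccc(F)c(Cl)c1` differs from compound 1 by fluoro in place of hydrogen on an aromatic carbon, and in this assay compound 3 gives 21600 nM. The step of a 1.3-fold higher number from compound 1 to compound 3 (0.12 log units; within the scatter) is also within the scatter, while a 2.1-fold higher number from compound 2 to compound 3 (0.33 log units; beyond the scatter) is modest.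

Compound 4 `C=CC(=O)Nc1cccc(NC(=O)CSc2nc(Nc3ccccc3F)c3ccccc3n2)c1` has not yet been measured. It differs from compound 2 by fluoro in place of hydrogen on an aromatic carbon. This is the same kind of change as that from compound 1 to compound 3, but not the same: there the fluoro sits ortho to a chloro group and para to a large group, here it sits ortho to a large group. Given that the earlier step of a 1.3-fold higher number from compound 1 to compound 3 (0.12 log units; within the scatter) was within the scatter, the step from compound 2 to compound 4 is expected to be a 1.1-fold higher number from compound 2 to compound 4 (0.05 log units; within the scatter), small and within the scatter. Compound 4 is therefore estimated to give 11500 nM in this assay, between 6000 nM and 23000 nM.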

Compound 4, half-maximal inhibitory concentration: 18700 nM
Compound 4: the middle estimate sits 1.6-fold (0.21 log units) below what was measured; measured number inside the range.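

In this assay, fluoro in place of hydrogen on the anilino ring gives a 1.8-fold higher number from compound 2 to compound 4 (0.26 log units; within the scatter), a step that stays within the scatter. Set beside the earlier fluoro step on the core of compound 1, the two steps cannot be told apart: the same change on two cores in this assay, a 1.3-fold higher number (0.12 log units; within the scatter) from compound 1 to compound 3 and a 1.8-fold higher number (0.26 log units; within the scatter) from compound 2 to compound 4, 1.4-fold (0.15 log units) apart, within the scatter of two such steps. Within the data shown here, this shows that, in these two pairs, adding fluoro left the number within the scatter on either core, but it does not establish a transferable effect, since both steps are small, only two pairs are available, and the fluoro stands on a different ring in each pair.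

The compounds shown leave open whether a larger group at the same place on the anilino ring, such as methoxy, trifluoromethyl or an amine, would carry the number beyond the scatter. They also leave open how a propanoylamino group, the saturated counterpart of the (vinylcarbonyl)amino group, would compare in this series.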